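Replacing a Linked Triazole with a Direct Imidazole

The source may hold more compounds than are shown below. What is called first, only, known or untested is meant among the compounds shown, and "the series" means these compounds.

Compound 1 `CC(C)C(c1ccc(-c2ccc3cccc(F)c3c2)[nH]c1=O)N1CCCCS1(=O)=O` and compound 2 `CC(C)C(Nc1nnc[nH]1)c1ccc(-c2ccc3cccc(F)c3c2)[nH]c1=O` share one core and differ only in the group on a saturated chain carbon bound to an aromatic carbon and a saturated chain carbon. In a functional assay on CHO cells for antagonist activity at prostaglandin E2 receptor EP3 subtype (Homo sapiens), read by cAMP accumulation (a higher number here means a weaker inhibitor, a lower number a stronger inhibitor), compound 1 gives 122 nM, and compound 2 gives 185 nM; the step of a 1.5-fold higher number from compound 1 to compound 2 (0.18 log units; within the scatter) shows that swapping one ring group for another at this place barely moved the number. Among the two measured compounds, compound 2 therefore stands together with compound 1 inside the scatter, and no order between them can be read. Compound 3 `Cc1c[nH]c(C(c2ccc(-c3ccc4cccc(F)c4c3)[nH]c2=O)C(C)C)n1` has not been measured; it differs from compound 2 by 4-methyl-1H-imidazol-2-yl in place of (4H-1,2,4-triazol-3-yl)amino on a saturated chain carbon bound to an aromatic carbon and a saturated chain carbon. Within the data shown here, the only step that bears on this place, the one from compound 1 to compound 2, was small, so the new change at the same site is expected to stay within the scatter: a 1.2-fold lower number from compound 2 to compound 3 (0.06 log units; within the scatter). Compound 3 is thus expected to give about 160 nM, most likely between 60 nM and 450 nM.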

Compound 3, half-maximal inhibitory concentration in the prostaglandin E2 receptor EP3 subtype assay: 36 nM
Estimate against measurement, compound 3: 4.4-fold (0.65 log units) above; the measured number lies below the stated range.
By their numbers in the prostaglandin E2 receptor EP3 subtype assay, from the lowest: compound 3; then compounds 1 and 2 (each within the scatter of the next).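

In the prostaglandin E2 receptor EP3 subtype assay, 4-methyl-1H-imidazol-2-yl in place of (4H-1,2,4-triazol-3-yl)amino gives a step beyond the scatter (a 5.1-fold lower number from compound 2 to compound 3 (0.71 log units; beyond the scatter)), and the same group in place of the six-membered non-aromatic ring group also gives one (a 3.4-fold lower number from compound 1 to compound 3 (0.53 log units; beyond the scatter)), so this place does respond to the group it carries, which the step between compound 1 and compound 2 could not show. In a physicochemical assay for solubility, in phosphate buffer, measured as kinetic solubility (a lower number here means a less soluble compound, a higher number a more soluble compound), compound 2 gives 17200 nM and compound 3 gives 15200 nM, which stand within the scatter of each other (a 1.1-fold lower number from compound 2 to compound 3 (0.05 log units; within the scatter)). No measurement given here accounts for the step in inhibition.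

The compounds shown do not separate what the methyl contributes from what the imidazole ring contributes. A plain 1H-imidazol-2-yl, or an ethyl in place of the methyl, would bear on that question.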